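The source may report more compounds than this note shows. Statements on the series, on what has been measured and on what is new or still open speak of the compounds shown alone.

Compound 1 `CCCCCCCCCOC(=O)CCC(=O)N1CCN(CCCOc2cc3c(Nc4ccc(F)c(Cl)c4)ncnc3cc2OC)CC1` gives 7.8%
Compound 2 `CCCCCCCCCCOC(=O)CCC(=O)N1CCN(CCCOc2cc3c(Nc4ccc(F)c(Cl)c4)ncnc3cc2OC)CC1` gives 2%
Compound 3 `CCCCCCCCCCCCCCOC(=O)CCC(=O)N1CCN(CCCOc2cc3c(Nc4ccc(F)c(Cl)c4)ncnc3cc2OC)CC1` gives 77.2%

These three compounds were tested in a functional assay on A549 cells (Homo sapiens) for cytotoxicity, read by MTT assay, with a stated time of 24 h, tested at 80 uM; a lower number here means a stronger effect, a higher number a weaker effect of the compound at the concentration tested. Compound 4 `CCCCCCCCCCCCCCCOC(=O)CCC(=O)N1CCN(CCCOc2cc3c(Nc4ccc(F)c(Cl)c4)ncnc3cc2OC)CC1` has not yet been measured there. Compound 2 differs from compound 1 by methyl in place of hydrogen on a saturated chain carbon, nine bonds along the chain from an oxygen next to a carbonyl group, and that change made a step of a number 5.8 percentage points lower from compound 1 to compound 2 (within the scatter). Compound 4 differs from compound 3 by methyl in place of hydrogen on a saturated chain carbon, ten or more bonds along the chain from an oxygen next to a carbonyl group. This is the same kind of change, but the place on the chain differs, as the two descriptions of the change show. The cores of compound 1 and compound 3 differ by pentyl in place of hydrogen on a saturated chain carbon, nine bonds along the chain from an oxygen next to a carbonyl group, a change that made the step of a number 69.4 percentage points higher from compound 1 to compound 3 (beyond the scatter). From compound 3 to compound 4 a small step is expected, a number 4.8 percentage points higher from compound 3 to compound 4 (within the scatter), because the earlier methyl addition stayed within the scatter a number 5.8 percentage points lower from compound 1 to compound 2 (within the scatter). The number for compound 3 77.2% is already high, which leaves limited room to rise. Compound 4 is estimated at 82%, with a likely range from 55% to 100%.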

Compound 4, a percentage reported as activity, at one concentration (the size of the read-out at that concentration, not a potency): 81.1%
Beside the measured number, compound 4's estimate is 0.9 percentage points above it; low and high end bracket the measured number.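

In this assay, among these compounds, the methyl addition came out alike on both cores, with a step of a number 3.9 percentage points higher from compound 3 to compound 4 (within the scatter): the same change on two cores in this assay, a number 5.8 percentage points lower (within the scatter) from compound 1 to compound 2 and a number 3.9 percentage points higher (within the scatter) from compound 3 to compound 4, 9.7 percentage points apart, within the scatter of two such steps The larger lengthening also came out alike, with the pentyl change giving a step of a number 79.1 percentage points higher from compound 2 to compound 4 (beyond the scatter) and the hexyl change giving a step of a number 73.3 percentage points higher from compound 1 to compound 4 (beyond the scatter): the same change on two cores in this assay, a number 69.4 percentage points higher (beyond the scatter) from compound 1 to compound 3 and a number 79.1 percentage points higher (beyond the scatter) from compound 2 to compound 4, 9.7 percentage points apart, within the scatter of two such steps So a methyl step stayed small on both the shorter and the longer chains, and a large step appeared again when a short chain was compared with a long one, but this rests on only two pairs of steps on one chain at a single concentration and does not show how these changes would carry to other cores.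

The compounds shown leave open where the large rise sets in among chain lengths between those of compound 2 and compound 3. They also leave open how a longer chain, or a carboxylic acid at the chain end, would behave.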